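A few compounds are considered here, and "the series" means these few. Any claim that something is new, unique, unknown or untested is made for them only; others in the source may bear on it.

Compound 1 `CN(C)CC[C@H](CSc1ccccc1)Nc1ccc(S(=O)(=O)NC(=O)c2ccc(N3CCN(Cc4ccccc4-c4ccc(Cl)cc4)CC3)cc2)cc1OC(F)(F)F`: 5080 nM
Compound 2 `CN(C)CC[C@H](CSc1ccccc1)Nc1ccc(S(=O)(=O)NC(=O)c2ccc(N3CCN(CC4=C(c5ccc(Cl)cc5)CCOC4)CC3)cc2)cc1[N+](=O)[O-]`: 266 nM
Compound 3 `CN(C)CC[C@H](CSc1ccccc1)Nc1ccc(S(=O)(=O)NC(=O)c2ccc(N3CCN(CC4=C(c5ccc(Cl)cc5)CCCC4)CC3)cc2)cc1[N+](=O)[O-]`: 25.7 nM

In a functional assay on NCI-H146 cells (Homo sapiens) for cytotoxicity, with a stated time of 48 h, in the presence of a further agent that is not named here (a lower number here means that less compound is needed, a higher number that more compound is needed for the effect), compound 1 gives the highest of the three numbers. Compound 2 stands at 266 nM and compound 3 at 25.7 nM; both lie well below the number of compound 1, but each of these two compounds differs from compound 1 in more than one place, so no single step can be read from them. Compound 4 `CN(C)CC[C@H](CSc1ccccc1)Nc1ccc(S(=O)(=O)NC(=O)c2ccc(N3CCN(Cc4ccccc4-c4ccc(Cl)cc4)CC3)cc2)cc1C(=O)C(F)(F)F` differs from compound 1 in one place: (trifluoromethyl)carbonyl in place of trifluoromethoxy on an aromatic carbon. For the measured compounds named here, no measured pair shows this change on its own. The step of a 2.0-fold lower number from compound 1 to compound 4 (0.31 log units; beyond the scatter) is therefore expected to be small, toward a lower number, and may not exceed the scatter. For compound 4 the expected value is 2500 nM, with a range from 600 nM to 9000 nM.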

Compound 4, half-maximal effective concentration: 2010 nM
Estimate against measurement, compound 4: 1.2-fold (0.09 log units) above, and the stated range covers the measured number.
By their numbers in this assay, from the lowest: compound 3; then compound 2; then compound 4; then compound 1.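

In this assay, for the compounds shown here, exchanging trifluoromethoxy for (trifluoromethyl)carbonyl on this aromatic carbon gives a 2.5-fold lower number from compound 1 to compound 4 (0.40 log units; beyond the scatter), the first step that can be read on its own. At this position, with the rest of compound 1 unchanged, the exchange moves the number down modestly, though beyond the scatter. No measurement shown here accounts for the step. As far as these compounds go, how a nitrile or an amine on the same aromatic carbon would compare remains open, as does whether this step would recur on the other side chains of compound 2 and compound 3.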